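Changing fluoro to chloro on a phenyl nucleoside

The compounds below may be only part of what the source reports. "The series", "measured", "known", "first", "only" and "open" are said of these compounds alone.

Measured in a functional assay on HL-60 cells (Homo sapiens) for cytotoxicity, read by XTT assay, with a stated time of 3 days; a lower number here means a stronger inhibitor, a higher number a weaker inhibitor:
- Compound 1 `OC[C@H]1O[C@@H](n2cc(F)c3c(-c4ccccc4)ncnc32)[C@H](O)[C@@H]1O`: > 40000 nM
- Compound 2 `OC[C@H]1O[C@@H](n2cc(F)c3c(-c4cccs4)ncnc32)[C@H](O)[C@@H]1O`: 4300 nM

Compound 1 stands at the limit of > 40000 nM in this assay, at which 1 of the 2 values shown sits, which is a limit and not a number. Compound 3 `OC[C@H]1O[C@@H](n2cc(Cl)c3c(-c4ccccc4)ncnc32)[C@H](O)[C@@H]1O` keeps the phenyl of compound 1 but differs on the core: chloro in place of fluoro on an aromatic carbon.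

Within the data shown here, the only measured step, an at least 9.3-fold lower number from compound 1 to compound 2 (0.96 log units; beyond the scatter), puts thiophen-2-yl in place of phenyl. Among the measured compounds shown here, it is a sizeable step, but it concerns a different change, and no measured step swaps fluoro for chloro. With the phenyl of compound 1 retained, only a small move towards a lower number is expected in this assay, possibly none beyond the scatter. The expected step is an at least 1.4-fold lower number from compound 1 to compound 3 (0.15 log units; that floor lies within the scatter). For compound 3 the estimated value is 28000 nM, with an expected range of 9000 nM to 40000 nM.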

Compound 3, half-maximal inhibitory concentration: 1200 nM
The estimate for compound 3 lay 23-fold (1.37 log units) above the measured number; measured number below the stated range.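

In this assay, replacing fluoro with chloro on the shared core gives an at least 33-fold lower number from compound 1 to compound 3 (1.52 log units; beyond the scatter). Among these compounds, the earlier compounds showed only that the number could move when thiophen-2-yl replaced phenyl; this step shows that a single halogen swap on an aromatic carbon of the five-membered ring, with the phenyl kept, can also have a large effect. The true size of the step cannot be stated because compound 1 has a limit and not a number: the limit of > 40000 nM in this assay, at which 1 of the 3 values shown sits.

Whether chloro would give a similar step with thiophen-2-yl in place of phenyl remains open, as the compounds shown do not include that combination. Also open, on these data alone, is how bromo, methyl or a nitrile at this same carbon would compare with chloro.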